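Benzyl on the Phosphate of a Thiosugar Inhibitor

This account rests on a few compounds, and the source may have more. Where it says the series, first, only, none or still open, it means among the compounds named here.

Measured so far:
- compound 1 `COC1SC(C)C(O)C(O)C1O`: 690000 nM
- compound 2 `CC1SC(OP(=O)(O)O)C(O)C(O)C1O`: 406000 nM

Compound 1 `COC1SC(C)C(O)C(O)C1O` was tested in an assay on isolated protein for inhibition of tissue alpha-L-fucosidase (Homo sapiens) (on this read-out higher numbers stand for weaker inhibition and lower numbers for stronger inhibition), and gives 690000 nM. Compound 2 `CC1SC(OP(=O)(O)O)C(O)C(O)C1O`, in which a phosphate group replaces the methyl on the ring-attached oxygen, gives 406000 nM in this assay. Of the two numbers compound 2 has the lower one, but the step of a 1.7-fold lower number from compound 1 to compound 2 (0.23 log units; within the scatter) stays within the scatter, so the two compounds cannot be told apart on this read-out.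

Compound 3 `CC1SC(OP(=O)(O)OCc2ccccc2)C(O)C(O)C1O` takes the next step from compound 2: benzyl in place of hydrogen on an oxygen. Among the measured compounds shown here, only one measured step exists, and it touched the same oxygen region, giving a 1.7-fold lower number from compound 1 to compound 2 (0.23 log units; within the scatter); it says nothing about a benzyl on a phosphate oxygen. For the measured compounds named here, with that single, small step as the only guide, no change beyond the scatter is expected in this assay, and the estimated step of a 1.4-fold lower number from compound 2 to compound 3 (0.13 log units; within the scatter) is accordingly small. For compound 3 the expected value in this assay is therefore 300000 nM, with a range from 80000 nM to 1200000 nM.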

Compound 3, inhibition constant: 33000 nM
Compound 3: the middle estimate sits 9.1-fold (0.96 log units) above what was measured; the whole stated range lies above it.
By their numbers in this assay, from the lowest: compound 3; then compounds 2 and 1 (each within the scatter of the next).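

In this assay, this oxygen turns out to be a place where a change can register: benzyl in place of hydrogen, on an oxygen whose other neighbours are phosphorus, gives a 12-fold lower number from compound 2 to compound 3 (1.09 log units; beyond the scatter) and so lies beyond the scatter. The earlier step, a 1.7-fold lower number from compound 1 to compound 2 (0.23 log units; within the scatter) and likewise read as within the scatter, swapped a methyl for a phosphate group and left the two compounds impossible to tell apart, so it gave no sign that a change on the phosphate could move the number this far. No measurement at hand explains the size of this step.

The compounds shown leave open whether the aromatic ring of the benzyl matters or whether other carbon groups on the same oxygen, such as a plain methyl, a longer butyl chain or a saturated cyclohexylmethyl, would lower the number as well. They also leave open whether an amine or a carboxylic acid carried on the benzyl ring would move the number further in either direction.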